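Truncating the biaryl of compound 3 to an ethyl group

The source may hold more compounds than are shown below. What is called first, only, known or untested is meant among the compounds shown, and "the series" means these compounds.

Compound 3 `COc1ccccc1-c1ccc(S(=O)(=O)N2CCC(N3CCC(C)CC3)CC2)cc1` holds the lowest of the two numbers obtained in a functional assay on DLD-1 cells (Homo sapiens) for antiproliferative activity, read by CellTiter-Glo, with a stated time of 72 h (on this read-out higher numbers stand for weaker inhibition and lower numbers for stronger inhibition), at 26 nM. Compound 1 `Cc1cc(C)c(S(=O)(=O)N2CCN(C3CN4CCC3CC4)CC2)c(C)c1` in this assay gives 84 nM, a gap beyond the usual scatter. Compound 2 `COc1cc(C)ccc1S(=O)(=O)N1CCC(N2CCC(C)CC2)CC1` returns no number in this assay, only a limit at > 5000 nM; this is the assay ceiling (the limit of > 5000 nM in this assay, at which 1 of the 3 values shown sits). Compound 4 `CCc1ccc(S(=O)(=O)N2CCC(N3CCC(C)CC3)CC2)cc1` is derived from compound 3 by one change: ethyl in place of 2-methoxyphenyl on an aromatic carbon. Within the data shown here, no measured pair shares this exact change, so its size is unknown; a step toward weaker inhibition is expected. That expectation rests on compound 2, whose result in this assay is a limit, > 5000 nM. Compound 4 is expected near 1500 nM, within 300 nM to 5000 nM, a step of a 58-fold higher number from compound 3 to compound 4 (1.76 log units; beyond the scatter).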

Compound 4, half-maximal inhibitory concentration: > 5000 nM
Compound 4 ended at the assay's limit; the forecaster's own chance of this, stated with the estimate: 35%; middle value at least 3.3-fold (0.52 log units) from the limit.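

Among these compounds, compound 3 and compound 4 give the first comparison in which only this position changes: in this assay, ethyl in place of 2-methoxyphenyl gives an at least 190-fold higher number from compound 3 to compound 4 (2.28 log units; beyond the scatter). The result for compound 4 is a limit, not a number, so the step has only a lower bound. On this core, ethyl on this aromatic carbon does not retain the activity of compound 3, and the assay ceiling now holds a second compound: the limit of > 5000 nM in this assay, at which 2 of the 4 values shown sit.

Going by these compounds, it remains open whether the activity depends on the aromatic ring itself or on its methoxy group. A plain phenyl or a butyl chain here would help separate these.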